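Chloroanilino Replaces Fluorophenyl on a Trimethoxybenzoyl Benzothiophene

The source may report more compounds than this note shows. Statements on the series, on what has been measured and on what is new or still open speak of the compounds shown alone.

Measured compounds:
compound 1 `COc1cc(C(=O)c2sc3ccccc3c2-c2ccc(F)cc2)cc(OC)c1OC` — 3200 nM
compound 2 `CCOc1ccc(-c2c(C(=O)c3cc(OC)c(OC)c(OC)c3)sc3ccccc23)cc1` — 3100 nM
compound 3 `COc1cc(C(=O)c2sc3ccccc3c2Nc2ccccc2)cc(OC)c1OC` — 3000 nM

Of the compounds shown here, three sharing the same core have been tested in a functional assay on A549 cells (Homo sapiens) for antiproliferative activity, read by MTT assay, with a stated time of 72 h; a higher number here means a weaker inhibitor, a lower number a stronger inhibitor. Compound 1 gives 3200 nM, and the other two numbers sit within the scatter of it: the step of a 1.0-fold lower number from compound 1 to compound 2 (0.01 log units; within the scatter) and the step of a 1.1-fold lower number from compound 1 to compound 3 (0.03 log units; within the scatter) are both too small to separate the compounds, as is the step of a 1.0-fold lower number from compound 2 to compound 3 (0.01 log units; within the scatter). Compound 1 therefore stands among equals rather than apart from them.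

Compound 4 `COc1cc(C(=O)c2sc3ccccc3c2Nc2ccc(Cl)cc2)cc(OC)c1OC` has not yet been measured. It differs from compound 1 as follows: (4-chlorophenyl)amino in place of 4-fluorophenyl on an aromatic carbon.

Among the compounds with values here, the step that bears most directly on this change is the one from compound 1 to compound 3, where an anilino group took the place of the 4-fluorophenyl group and the number moved by a 1.1-fold lower number from compound 1 to compound 3 (0.03 log units; within the scatter), within the scatter. The change to compound 4 is of the same kind, adding a chlorine to that anilino group. Nothing among the three measured compounds shows any step beyond the scatter, so no shift beyond the scatter is expected in this assay.

Compound 4 is therefore estimated at 3000 nM, with a range from 1200 nM to 8000 nM, corresponding to an expected step of a 1.1-fold lower number from compound 1 to compound 4 (0.03 log units; within the scatter).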

Compound 4, half-maximal inhibitory concentration: 3100 nM
Estimate against measurement, compound 4: 1.0-fold (0.01 log units) below, within the range that was stated.
By their numbers in this assay, from the lowest: compounds 3, 2, 4 and 1 (each within the scatter of the next).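

In this assay, within the data shown here, the chloro group is the first change made on the anilino ring itself, and the step of a 1.0-fold higher number from compound 3 to compound 4 (0.01 log units; within the scatter) shows that chloro in place of hydrogen there does not separate the two compounds. Exchanging the whole group on this aromatic carbon of the five-membered aromatic ring with 1 sulfur gives the same picture, with the step of a 1.0-fold lower number from compound 1 to compound 4 (0.01 log units; within the scatter) and the step of no change at the digits printed from compound 2 to compound 4 (within the scatter) both too small to count. So (4-chlorophenyl)amino, which carries a hydrogen-bond donor that 4-fluorophenyl and 4-ethoxyphenyl do not, cannot be told apart from either of them in this set, and all four compounds remain together within the scatter.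

The compounds shown leave open whether a carboxylic acid or a dimethylamino group on the anilino ring would move the number beyond the scatter in this assay at all. They also leave open what a methyl group on the anilino nitrogen would do at this position, or a longer chain in place of the ethoxy group. Nothing available here explains why these numbers stay so close together.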